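The source may report more compounds than this note shows. Statements on the series, on what has been measured and on what is new or still open speak of the compounds shown alone.

Two cinnamanilides built on a trimethoxybenzophenone frame have been tested for their effect on the growth of cervical cancer cells. Compound 1 `COc1ccc(/C=C/C(=O)Nc2cc(C(=O)c3cc(OC)c(OC)c(OC)c3)ccc2OC)cc1` carries a 4-methoxyphenyl group on the double-bonded chain; in a functional assay on ME-180 cells (Homo sapiens) for cytotoxicity, read by MTT assay, with a stated time of 72 h (on this read-out higher numbers stand for weaker inhibition and lower numbers for stronger inhibition), compound 1 gives 11800 nM. Compound 2 `COc1cccc(/C=C/C(=O)Nc2cc(C(=O)c3cc(OC)c(OC)c(OC)c3)ccc2OC)c1` carries the methoxy group in the 3-position instead, and in this assay compound 2 gives 4300 nM. Moving the methoxy group changes the read-out by a 2.7-fold lower number from compound 1 to compound 2 (0.44 log units; beyond the scatter), so compound 2 holds the lower of the two numbers recorded so far.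

Compound 3 `C#CCOc1cccc(/C=C/C(=O)Nc2cc(C(=O)c3cc(OC)c(OC)c(OC)c3)ccc2OC)c1` keeps the frame of compound 2 and differs from it only by ethynyl in place of hydrogen on a saturated chain carbon bound to an oxygen on an aromatic ring. Among the compounds with values here, no measured step shows what lengthening this alkoxy group does; the only step available, from compound 1 to compound 2, concerns a change of position, not of size. The expected outcome for compound 3 is therefore close to compound 2, a step of about a 1.1-fold lower number from compound 2 to compound 3 (0.03 log units; within the scatter) in this assay, with compound 3 estimated at 4000 nM, within a range from 1300 nM to 12000 nM.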

Compound 3, half-maximal inhibitory concentration: 15300 nM
For compound 3 the middle estimate is 3.8-fold (0.58 log units) below the measured one; the whole stated range lies below it.
By their numbers in this assay, from the lowest: compound 2; then compounds 1 and 3 (each within the scatter of the next).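

In this assay the methoxy group at this place does not tolerate every extension: ethynyl in place of hydrogen on the saturated chain carbon gives a 3.6-fold higher number from compound 2 to compound 3 (0.55 log units; beyond the scatter) and removes the advantage compound 2 held. The comparison with the other isomer gives a 1.3-fold higher number from compound 1 to compound 3 (0.11 log units; within the scatter) and so does not separate 3-(propargyloxy)phenyl from 4-methoxyphenyl in this read-out. Nothing available explains why the number rises with this change.

The compounds shown cannot tell whether the rise belongs to the triple bond or simply to a larger group on this oxygen, and a saturated propyl chain would help to separate those two readings. As far as these compounds go, whether an amine or a carboxylic acid at the end of such a chain would be tolerated also remains open.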